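The source may report more compounds than this note shows. Statements on the series, on what has been measured and on what is new or still open speak of the compounds shown alone.

The measured compounds:
Compound 1, `CC[C@H](C)[C@H](N)CN(C(=O)[C@@H]1C[C@H]1c1ccc(F)cc1)c1ccc(-c2ccccc2)cc1`; in a functional assay for agonist activity at G protein-coupled receptor 88 (Homo sapiens), read by HTRF and cAMP accumulation (a higher number here means that more compound is needed for the effect, a lower number that less compound is needed), compound 1 gives 600 nM.
Compound 2, `CC[C@H](C)[C@H](N)CN(C(=O)[C@@H]1C[C@H]1c1ccccn1)c1ccc(-c2ccccc2)cc1`; in this assay compound 2 gives 130 nM.
Compound 3, `CC[C@H](C)[C@H](N)CN(C(=O)[C@@H]1C[C@H]1c1ncccn1)c1ccc(-c2ccccc2)cc1`; in this assay compound 3 gives 130 nM.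

Compound 3 stands level with compound 2 at the digits shown, and together the two have the lowest numbers of the three in this assay; the remaining compound, compound 1, sits higher, a 4.6-fold lower number from compound 1 to compound 3 (0.66 log units; beyond the scatter). Compound 4 is `CC[C@H](C)[C@H](N)CN(C(=O)[C@@H]1C[C@H]1c1nc(C)cs1)c1ccc(-c2ccccc2)cc1`, not yet measured. It differs from compound 3 in one place: 4-methyl-1,3-thiazol-2-yl in place of pyrimidin-2-yl on a saturated ring carbon. For the measured compounds named here, two of the earlier steps replaced the 4-fluorophenyl on the same saturated ring carbon with a six-membered aromatic ring with hetero atoms, a 4.6-fold lower number from compound 1 to compound 2 (0.66 log units; beyond the scatter) and a 4.6-fold lower number from compound 1 to compound 3 (0.66 log units; beyond the scatter), both beyond the scatter. The third step exchanged one such ring for another, no change at the digits printed from compound 2 to compound 3 (within the scatter), and left the number where it was. The change to compound 4 again swaps one ring with two hetero atoms and two hydrogen-bond acceptors for another, here a five-membered one. Going by the values given here, no measured step covers a five-membered ring or sulfur, so the expectation rests on the small effect seen when one heteroaryl replaced another. Compound 4 is therefore expected to sit close to compound 3, a 1.2-fold higher number from compound 3 to compound 4 (0.06 log units; within the scatter), with a range widened for the untested ring. The estimate for compound 4 is 150 nM, between 60 nM and 400 nM.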

Compound 4, half-maximal effective concentration: 730 nM
Beside the measured number, compound 4's estimate is 4.9-fold (0.69 log units) below it; measured number above the stated range.
By their numbers in this assay, from the lowest: compounds 2 and 3 (each within the scatter of the next); then compounds 1 and 4 (each within the scatter of the next).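

In this assay this position on the three-membered ring does not treat all heteroaryl groups alike: swapping pyridin-2-yl for pyrimidin-2-yl left the number unchanged, yet there is a 5.6-fold higher number from compound 3 to compound 4 (0.75 log units; beyond the scatter) and likewise a 5.6-fold higher number from compound 2 to compound 4 (0.75 log units; beyond the scatter) when 4-methyl-1,3-thiazol-2-yl enters, even though the heavy-atom and hydrogen-bond acceptor counts of the pyrimidin-2-yl and 4-methyl-1,3-thiazol-2-yl groups match. The lower number seen on leaving 4-fluorophenyl therefore holds for compound 2 and compound 3 but not for compound 4, since there is only a 1.2-fold higher number from compound 1 to compound 4 (0.09 log units; within the scatter) and the step stays within the scatter. Nothing shown here offers a measured account of why the 4-methyl-1,3-thiazol-2-yl group behaves differently.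

Compound 4 brings a five-membered ring, a sulfur atom and a methyl group in a single change, so the compounds shown cannot assign the step to any one of these. The plain 1,3-thiazol-2-yl group, without the methyl, and the 4-methylpyrimidin-2-yl group, which keeps the methyl on the six-membered ring, would pull these features apart.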